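The source may hold more compounds than are shown below. What is called first, only, known or untested is meant among the compounds shown, and "the series" means these compounds.

Compound 1 `Cc1ccc(N2CCN(C(=O)[C@@H]3CN(C4CCOCC4)C[C@H]3c3ccc(Cl)cc3)CC2)c([C@@H](NC(=O)[C@@H](C)N)C(C)C)c1` and compound 2 `Cc1ccc(N2CCN(C(=O)[C@@H]3CNC[C@H]3c3ccc(Cl)cc3)CC2)c([C@@H](NC(=O)CCN(C)C)C(C)C)c1` were both tested in a functional assay on CHO cells with Melanocortin receptor 4 (Homo sapiens) as the target, read by cAMP accumulation; on this read-out higher numbers stand for larger maximal responses and lower numbers for smaller maximal responses. In this assay compound 1 gives 56%, the lower of the two numbers. Compound 2 gives 72%, a result that sits above compound 1 by more than the usual scatter. Compound 1 and compound 2 differ at more than one place, so their two values say nothing about any single structural change.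

Compound 3 `CNCC(=O)N[C@H](c1cc(C)ccc1N1CCN(C(=O)[C@@H]2CN(C3CCOCC3)C[C@H]2c2ccc(Cl)cc2)CC1)C(C)C` has not yet been measured in this assay. It differs from compound 1 in one place: (methylamino)methyl in place of 1-aminoethyl on a carbonyl carbon. The two compounds are built from the same atoms, joined differently, and the group that enters keeps the same count of hydrogen-bond donors and acceptors as the group that leaves.

Among the measured compounds shown here, no measured pair shows what this kind of change does here. With nothing else to go on, the step from compound 1 to compound 3 is expected to be small, and a number 4 percentage points higher from compound 1 to compound 3 (within the scatter) is the estimate for it. For compound 3 the maximal response in this assay is therefore expected to be about 60%, most likely between 42% and 78%.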

Compound 3, intrinsic activity: the largest response reached, in percent of the reference agonist's: 84%
Estimate against measurement, compound 3: 24 percentage points below; measured number outside the range, above it.
By their numbers in this assay, from the lowest: compound 1; then compound 2; then compound 3.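

On the carbonyl carbon of this side chain, the way the atoms are joined matters, not only which atoms are present: in this assay, placing (methylamino)methyl in place of 1-aminoethyl gives a number 28 percentage points higher from compound 1 to compound 3 (beyond the scatter), even though the heavy-atom, hydrogen-bond donor and hydrogen-bond acceptor counts stay the same. Among the compounds shown here, this single-place comparison is the first one available here, and it also shows that the step combines two changes, since the group that leaves has a defined stereocentre and the group that enters has none. Nothing measured here explains the rise in maximal response.

The compounds shown leave open whether the gain follows the methyl on the nitrogen, the loss of the branch with its stereocentre, or both together. Aminomethyl, which has neither that methyl nor that branch, and (dimethylamino)methyl, which has a second methyl on the nitrogen, would be informative groups to compare on the core of compound 1.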